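A Single Fluoro Change on a Cytotoxic Compound

A few compounds are considered here, and "the series" means these few. Any claim that something is new, unique, unknown or untested is made for them only; others in the source may bear on it.

For the measured compounds named here, in a functional assay on A549 cells (Homo sapiens) for cytotoxicity, read by WST assay, with a stated time of 24 h (a lower number here means a stronger inhibitor, a higher number a weaker inhibitor), compound 1 (`COc1ccc2[nH]cc(/C=C(\C#N)C(=O)c3c[nH]c4ccccc34)c2c1`) gives 6600 nM, the only exact number so far. Compound 2 (`COc1ccc2[nH]cc(/C=C(\C#N)C(=O)c3c[nH]c4ccc(OC)cc34)c2c1`) gives > 50000 nM, which is a limit of the assay. Compound 3 (`COc1ccc2[nH]cc(/C=C(\C#N)C(=O)c3c[nH]c4cc(F)ccc34)c2c1`) differs from compound 1 by fluoro in place of hydrogen on an aromatic carbon. Going by the values given here, the sole measured step, an at least 7.5-fold higher number from compound 1 to compound 2 (0.87 log units; beyond the scatter), lies beyond the scatter and came with methoxy in place of hydrogen on an aromatic carbon. It is only a loose guide to a fluoro change, so a small rise in the number is expected in this assay. The expected step is a 1.4-fold higher number from compound 1 to compound 3 (0.13 log units; within the scatter). For compound 3 the estimated value is 9000 nM, within an expected range of 3000 nM to 30000 nM.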

Compound 3, half-maximal inhibitory concentration: 18000 nM
Compound 3: middle estimate off by 2.0-fold (0.30 log units), on the low side; low and high end bracket the measured number.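

In this assay, fluoro in place of hydrogen on an aromatic carbon gives a 2.7-fold higher number from compound 1 to compound 3 (0.44 log units; beyond the scatter), so even this single heavy atom on the ring moves the number beyond the scatter. Compounds 2 and 3 both read weaker than compound 1, and compound 3 gives an exact size for such a step. The methoxy step gives no exact size, as compound 2 stands at a limit: the limit of > 50000 nM in this assay, at which 1 of the 3 values shown sits.

On these data alone, it remains open how an amine or a carboxylic acid at this carbon would read. As far as these compounds go, it is also open whether fluoro on the carbon that carries methoxy in compound 2 would give a similar step.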